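The source may hold more compounds than are shown below. What is called first, only, known or untested is meant among the compounds shown, and "the series" means these compounds.

Working notes on the series.

Compound 1 `N[C@H]1CC[C@H](Nc2c(C(=O)NCc3ccc(Oc4ccccc4)cc3)nc(Br)c3cccnc23)CC1` and compound 2 `N[C@H]1CC[C@H](Nc2c(C(=O)NC3CCCCC3)nc(Br)c3cccnc23)CC1` share one core and differ only in the amide substituent. In a functional assay on HEY cells (Homo sapiens) for cytotoxicity, read by MTT assay, with a stated time of 72 h (a higher number here means a weaker inhibitor, a lower number a stronger inhibitor), compound 1 gives 9000 nM, the highest of the two numbers recorded so far, while compound 2 gives 5200 nM in this assay; the two values sit within the scatter of each other, so no order between compound 1 and compound 2 can be read from them.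

Compound 3 `N[C@H]1CC[C@H](Nc2c(C(=O)NCc3ccccc3)nc(Br)c3cccnc23)CC1` has not yet been measured. Relative to compound 1 it carries hydrogen in place of phenoxy on an aromatic carbon, that is, the phenoxy is removed and hydrogen stands on that aromatic carbon. Going by the values given here, no measured pair in the set reports what this change does. Given that compound 1 at 9000 nM and compound 2 at 5200 nM differ by less than the scatter despite quite different amide substituents, the step from compound 1 to compound 3 in this assay is expected to be small, with no direction beyond the scatter, a 1.2-fold lower number from compound 1 to compound 3 (0.08 log units; within the scatter). For compound 3 in this assay the estimate is 7500 nM, with a range from 2500 nM to 22000 nM.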

Compound 3, half-maximal inhibitory concentration: 8000 nM
Estimate against measurement, compound 3: 1.1-fold (0.03 log units) below, within the range that was stated.
By their numbers in this assay, from the lowest: compounds 2, 3 and 1 (each within the scatter of the next).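

In this assay, hydrogen in place of phenoxy on an aromatic carbon, para to a large group, gives a 1.1-fold lower number from compound 1 to compound 3 (0.05 log units; within the scatter), so losing this whole six-membered aromatic ring leaves two numbers that cannot be told apart. Benzyl in place of cyclohexyl on an amide-type nitrogen gives a 1.5-fold higher number from compound 2 to compound 3 (0.19 log units; within the scatter), so neither single change separates compound 3 from its measured neighbours. Nothing available bears on why both steps are this small.

The compounds shown leave open whether an amine or a carboxylic acid on that aromatic carbon would give a step beyond the scatter. They also leave open whether a longer chain in place of benzyl on the amide-type nitrogen would do so.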